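Replacing a primary amine with a bridged bicyclic amine

A few compounds are considered here, and "the series" means these few. Any claim that something is new, unique, unknown or untested is made for them only; others in the source may bear on it.

Among the measured compounds shown here, compound 3 `Nc1ccc2cc(NC(=O)CCc3ccc(C(F)(F)F)cc3)ccc2n1` stands highest of the three numbers so far in an assay on isolated protein for displacement of a labelled ligand from melanin-concentrating hormone receptor 1 (Homo sapiens) (a higher number here means a weaker inhibitor, a lower number a stronger inhibitor), where compound 3 gives 240 nM. The two other measured compounds carry a saturated nitrogen ring at the same position on the shared core: compound 1 `CC1CCN(c2ccc3cc(NC(=O)CCc4ccc(C(F)(F)F)cc4)ccc3n2)C1` gives 2 nM in this assay, and compound 2 `CC(C)C(=O)NC1CCN(c2ccc3cc(NC(=O)CCc4ccc(C(F)(F)F)cc4)ccc3n2)C1` gives 1 nM. Going to the primary amine produces a 120-fold higher number from compound 1 to compound 3 (2.08 log units; beyond the scatter) and a 240-fold higher number from compound 2 to compound 3 (2.38 log units; beyond the scatter), whereas the difference between the two ring-bearing compounds, a 2.0-fold lower number from compound 1 to compound 2 (0.30 log units; within the scatter), is small.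

Compound 4 `O=C(CCc1ccc(C(F)(F)F)cc1)Nc1ccc2nc(N3CC4CCC3CC4)ccc2c1` takes the opposite direction from compound 3: a group of 8 heavy atoms (7 carbon, 1 nitrogen; 2 six-membered non-aromatic rings with 1 hetero atom each) in place of one nitrogen atom, on an aromatic carbon. The two large steps from compound 1 and compound 2 to compound 3 bear directly on this change, since both show that a saturated nitrogen ring in place of the amino group is paired with a far lower number. A large step downward in this assay is therefore expected, an 80-fold lower number from compound 3 to compound 4 (1.90 log units; beyond the scatter). Compound 4 is estimated at 3 nM, with a range from 1 nM to 15 nM.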

Compound 4, half-maximal inhibitory concentration: 3 nM
Compound 4: the middle estimate sits on the measured number at the digits printed, and the stated range covers the measured number.
By their numbers in this assay, from the lowest: compounds 2, 1 and 4 (each within the scatter of the next, the first and the last beyond it); then compound 3.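

In this assay, the saturated nitrogen rings seen earlier each had one five-membered ring, and an 80-fold lower number from compound 3 to compound 4 (1.90 log units; beyond the scatter) shows that a group with 2 six-membered non-aromatic rings also goes with a far lower number than the amino group at this aromatic carbon. Against the smaller methyl-bearing ring, the change gives a 1.5-fold higher number from compound 1 to compound 4 (0.18 log units; within the scatter), so these two groups cannot be told apart here, while against the larger amide-bearing ring it gives a 3.0-fold higher number from compound 2 to compound 4 (0.48 log units; beyond the scatter), a modest step that shows the bicyclic group reaches a similar range without that amide side chain. No measurement shown explains these steps.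

The compounds shown leave open whether the bridge itself matters, which a plain piperidin-1-yl group at this carbon would test. They also leave open whether any ring is needed, which an open-chain dimethylamino group would address.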